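Shrinking the Amine Arm: From Pyrrolidine to Methylaminomethyl

A few compounds are considered here, and "the series" means these few. Any claim that something is new, unique, unknown or untested is made for them only; others in the source may bear on it.

Measured so far:
compound 1 `CCCCNCc1ccc(Cl)c(-c2ccccc2OC)c1`; compound 2 `COc1ccccc1-c1cc(C2CCN(C)C2)ccc1Cl`

In a functional assay on HEK293 cells for agonist activity at 5-hydroxytryptamine receptor 7 (Homo sapiens), read by a luciferase reporter and beta-arrestin recruitment, with a stated time of 22 h (on this read-out lower numbers stand for smaller maximal responses and higher numbers for larger maximal responses), compound 1 gave "not active" (no number reported) and no number. In this assay compound 2 reached 51%, the only numeric result so far, so it stands alone as the reference point. Compound 3 `CNCc1ccc(Cl)c(-c2ccccc2OC)c1` differs from compound 2 by (methylamino)methyl in place of 1-methylpyrrolidin-3-yl on an aromatic carbon. Among the compounds with values here, with no measured pair to show the size of such a change, the step of a number 21 percentage points lower from compound 2 to compound 3 (beyond the scatter) is expected to be a moderate fall rather than none. Compound 3 is therefore estimated at 30%, within 5% to 55%.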

Compound 3, largest response reached (Emax), in percent of the reference or control that the assay uses: 61%
Estimate against measurement, compound 3: 31 percentage points below; measured number above the stated range.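

this assay shows a number 10 percentage points higher from compound 2 to compound 3 (within the scatter) when (methylamino)methyl, with no ring and only 3 heavy atoms, replaces 1-methylpyrrolidin-3-yl, so at this position the ring is not needed for a clear response. Against compound 3, which shares its core, the longer chain on the amine nitrogen of compound 1 gives "not active" (no number reported) and shows that the arm's form can still matter. Nothing measured here explains these results. Still open, on these data alone, is how a plain aminomethyl or an ethylaminomethyl group would behave at this position.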